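Trading benzyloxy for a bromine-bearing amide group

This account rests on a few compounds, and the source may have more. Where it says the series, first, only, none or still open, it means among the compounds named here.

compound 1 `COc1cc(NC(=O)/C=C/c2cccc(OCc3ccccc3)c2)cc(OC)c1OC` gives 8500 nM
compound 2 `C=C(Br)C(=O)Nc1cccc(/C=C/C(=O)NCc2ccc(C)cc2)c1` gives 1300 nM
compound 3 `C=C(Br)C(=O)Nc1cccc(/C=C/C(=O)Nc2ccc(OC(F)(F)F)cc2)c1` gives 19300 nM

In a functional assay on SEM cells (Homo sapiens) for inhibition, read by MTT assay, with a stated time of 72 h (on this read-out higher numbers stand for weaker inhibition and lower numbers for stronger inhibition), compound 1 at 8500 nM holds the middle place of the three numbers, with compound 2 lower and compound 3 higher, both gaps beyond the usual scatter. Compound 4 `C=C(Br)C(=O)Nc1cccc(/C=C/C(=O)Nc2cc(OC)c(OC)c(OC)c2)c1` is still unmeasured. It differs from compound 1 by one change (((1-bromoethenyl)carbonyl)amino in place of benzyloxy on an aromatic carbon) with ((1-bromoethenyl)carbonyl)amino in place of benzyloxy on an aromatic carbon. Compound 2 and compound 3 carry that same group, yet compound 2 gives 1300 nM and compound 3 gives 19300 nM so the group alone sets no value. A moderate move toward a lower number, meaning stronger inhibition, is expected, and the estimated step is (a 2.4-fold lower number from compound 1 to compound 4 (0.39 log units; beyond the scatter)). Compound 4 is estimated at 3500 nM with an expected range from 700 nM to 15000 nM as the likely span.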

Compound 4, half-maximal inhibitory concentration: 18 nM
Beside the measured number, compound 4's estimate is 190-fold (2.29 log units) above it; measured number below the stated range.
By their numbers in this assay, from the lowest: compound 4; then compound 2; then compound 1; then compound 3.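

In this assay, replacing benzyloxy with ((1-bromoethenyl)carbonyl)amino gives a 470-fold lower number from compound 1 to compound 4 (2.67 log units; beyond the scatter) and shows that this single change on the aromatic carbon can have a very large effect on inhibition. Compound 2 and compound 3 carry the same group, but neither differs from compound 1 in only one place, so they could not isolate its effect. Nothing available explains why the step is so large. Still open, as far as these compounds go, is whether the bromine and the double bond are both needed, and how an acetylamino group or a plain amine at this position would compare.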